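A few compounds are considered here, and "the series" means these few. Any claim that something is new, unique, unknown or untested is made for them only; others in the source may bear on it.

Compound 2 `O=C(N/N=C/c1cc(I)c(O)c(I)c1)c1ccc(Cl)cc1` carries a chloro group on its outer aromatic ring. In a functional assay on HepG2 cells (Homo sapiens) for cytotoxicity, with a stated time of 24 h (on this read-out lower numbers stand for stronger inhibition and higher numbers for weaker inhibition), compound 2 gives > 100000 nM, which is a limit of the assay and not a number. Compound 1 `COc1ccc(C(=O)N/N=C/c2cc(I)c(O)c(I)c2)cc1` likewise gives > 100000 nM in this assay, again a limit. The step that the two limits leave unreadable from compound 1 to compound 2 therefore cannot be read, and the limit of > 100000 nM in this assay, at which 2 of the 2 values shown sit, is all the evidence there is. Compound 3 `O=C(N/N=C/c1cc(I)c(O)c(I)c1)c1ccc([N+](=O)[O-])cc1` differs from compound 2 by nitro in place of chloro on an aromatic carbon. With no readable step to draw on, compound 3 is expected to show no change beyond the scatter, an estimated step that the limit leaves unreadable from compound 2 to compound 3. The estimate for compound 3 is 150000 nM, spanning 40000 nM to 600000 nM.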

Compound 3, half-maximal inhibitory concentration: 92100 nM
Compound 3: the middle estimate sits 1.6-fold (0.21 log units) above what was measured, and the stated range covers the measured number.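

Among the compounds shown here, with nitro at this place, compound 3 gives the first actual number here, so a step can now be bounded from one side. Nitro in place of chloro gives an at least 1.0-fold lower number from compound 2 to compound 3 (0.03 log units; that floor lies within the scatter), and nitro in place of methoxy gives an at least 1.0-fold lower number from compound 1 to compound 3 (0.03 log units; that floor lies within the scatter). Both floors lie within the scatter, so the true size of either step stays unknown, and most of the values remain limits rather than numbers: the limit of > 100000 nM in this assay, at which 2 of the 3 values shown sit.

As far as these compounds go, whether an amine, a carboxylic acid or a longer chain at this place would give a lower number stays open. Also open, from the compounds shown here alone, is whether any group here can move the value beyond the scatter.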